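The source may report more compounds than this note shows. Statements on the series, on what has been measured and on what is new or still open speak of the compounds shown alone.

Measured so far:
compound 1, `Cc1ccc(N2CCN(C(=S)SCc3ccc4nc(N)nc(N)c4c3)CC2)cc1`, with 5510 nM in a functional assay on HCT-116 cells (Homo sapiens) for antiproliferative activity, read by MTT assay, with a stated time of 72 h; a higher number here means a weaker inhibitor, a lower number a stronger inhibitor;
compound 2, `Nc1nc(N)c2cc(CSC(=S)N3CCN(c4ccc(Cl)cc4)CC3)ccc2n1`, with 7380 nM in this assay.

Among the compounds with values here, compound 2 stands as the higher of the two numbers, but its neighbour compound 1 lies close by, and the one change known here, a 1.3-fold higher number from compound 1 to compound 2 (0.13 log units; within the scatter), is within the scatter. The unmeasured compound 3, `Nc1nc(N)c2cc(CSC(=S)N3CCN(c4ccc([N+](=O)[O-])cc4)CC3)ccc2n1`, differs from compound 2 by nitro in place of chloro on an aromatic carbon. Within the data shown here, the only step known in this set concerns the same position on the same ring, where a different group was exchanged, and that step did not move the number beyond the scatter. There is nothing here that shows a swap at this position shifting the number in either direction. On that basis compound 3 is expected to stay close to compound 2, giving a 1.1-fold lower number from compound 2 to compound 3 (0.02 log units; within the scatter) as the expected step. Compound 3 is therefore estimated at 7000 nM, within a range of 3000 nM to 16000 nM.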

Compound 3, half-maximal inhibitory concentration: 4680 nM
Compound 3: the middle estimate sits 1.5-fold (0.17 log units) above what was measured; the measured number falls inside the stated range.
By their numbers in this assay, from the lowest: compounds 3, 1 and 2 (each within the scatter of the next).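

In this assay nitro now joins chloro and methyl at this position: the exchange for chloro gives a 1.6-fold lower number from compound 2 to compound 3 (0.20 log units; within the scatter) and the exchange for methyl gives a 1.2-fold lower number from compound 1 to compound 3 (0.07 log units; within the scatter) and both steps lie within the scatter. Within the data shown here, the earlier compounds showed only one swap of a single group for another, whereas here 3 heavy atoms with 2 hydrogen-bond acceptors enter where 1 chlorine atom with no acceptor stood, and the number still stays within the scatter. Nothing given here accounts for this result.

The compounds shown leave open whether an amine, a carboxylic acid or a longer chain at this position would also stay within the scatter. Whether any group here can move the number beyond the scatter also remains open: all three steps among these compounds lie within it.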